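Stereocentre inversion in a thiadiazole quinuclidine pair

A few compounds are considered here, and "the series" means these few. Any claim that something is new, unique, unknown or untested is made for them only; others in the source may bear on it.

Measured compounds:
compound 1 `CCCCSc1nsnc1[C@H]1CN2CCC[C@@H]1C2` — > 0.3 mg/kg
compound 2 `CCCSc1nsnc1[C@H]1CN2CCC[C@@H]1C2` — 2.2 mg/kg

Going by the values given here, in a functional assay on the whole organism with Mus musculus as the target (a lower number here means that less compound is needed, a higher number that more compound is needed for the effect), compound 2 gives 2.2 mg/kg, the only number in this set. For compound 1 the result is a limit, > 0.3 mg/kg, as noted in the limit of > 0.3 mg/kg in this assay, at which 1 of the 2 values shown sits. The step that the limit leaves unreadable from compound 1 to compound 2 is therefore of unreadable size. Compound 3 `CCCSc1nsnc1[C@@H]1CN2CCC[C@@H]1C2` differs from compound 2 as follows: the two compounds have the same atoms and bonds; at least one stereo element is drawn with a configuration in one of them and without one in the other: 1 of 3 stereo elements differ; a stereocentre at a saturated ring carbon is drawn R in compound 2 and S in compound 3. Among the compounds with values here, no measured step concerns such a change of configuration, so no direction can be read from the data. Compound 3 is estimated at 4 mg/kg, between 1 mg/kg and 30 mg/kg, which is an expected step of a 1.8-fold higher number from compound 2 to compound 3 (0.26 log units; within the scatter).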

Compound 3, dose for half-maximal effect: > 30 mg/kg
Compound 3 was reported as a limit (the forecaster's own chance of this, stated with the estimate: 25%); middle value at least 7.5-fold (0.87 log units) away from the limit.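

Inverting one saturated ring carbon from R to S, with atoms and bonds unchanged, brings an at least 13-fold higher number from compound 2 to compound 3 (1.13 log units; beyond the scatter) in this assay, the first readable evidence in this set that configuration at this position matters. Compound 3 gives > 30 mg/kg, which is a limit of the assay. One caution applies to this comparison: the fact that one of compounds 2 and 3 is drawn with a defined configuration and the other without, at the place where they differ

The step between the two chain lengths cannot be read, so the effect of the chain remains undefined. On these data alone, whether this inversion has a similar effect with a pentyl chain on the sulfur, or with an amine in place of that sulfur chain, stays open.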